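Swapping the Ether Link for a Thioether in A549 Cells

The compounds below may be only part of what the source reports. "The series", "measured", "known", "first", "only" and "open" are said of these compounds alone.

Measured compounds:
compound 1 `Nc1cc(N)c2nc(-c3ccccc3)c(Oc3ccc(F)cc3)nc2c1`: 89100 nM
compound 2 `COc1ccc(CNc2nc3cc(N)cc(N)c3nc2-c2ccccc2)cc1`: < 100000 nM

Of the compounds shown here, two have been measured so far, both sharing a core that carries two amino groups and a phenyl group. In a functional assay on A549 cells (Homo sapiens) for inhibition, read by sulforhodamine B assay, with a stated time of 48 h (a higher number here means that more compound is tolerated, a lower number that less compound is tolerated), compound 1 gives 89100 nM. Compound 2 gives only a limit in this assay, < 100000 nM, which marks the edge of what the measurement reports rather than a number. Among the compounds with values here, compound 1 is therefore the only compound with a real number, the other value being a limit (the limit of < 100000 nM in this assay, at which 1 of the 2 values shown sits). Within the data shown here, no two measured compounds differ from each other in a single place, so no measured step is available to lean on.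

Compound 3 `COc1ccc(Sc2nc3cc(N)cc(N)c3nc2-c2ccccc2)cc1` has not yet been measured. It differs from compound 1 by (4-methoxyphenyl)sulfanyl in place of 4-fluorophenoxy on an aromatic carbon. Among the measured compounds shown here, with no measured step of this kind to draw on, the expectation is a small move toward a lower number, of about the size of the usual scatter and not clearly beyond it. For compound 3 the expected step is a 1.5-fold lower number from compound 1 to compound 3 (0.17 log units; within the scatter). Compound 3 is therefore estimated at 60000 nM, with a plausible range from 20000 nM to 150000 nM in this assay.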

Compound 3, concentration lethal to 50% of the cells: < 100000 nM
Compound 3 gave a limit, no number; the forecaster's own chance of this, stated with the estimate: 35%; the middle value lies beyond the limit too.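

In this assay, within the data shown here, compound 3 gives only a limit of < 100000 nM and so no step from compound 1 to compound 3 can be read (the result joins compound 2 at the edge of the measurement: the limit of < 100000 nM in this assay, at which 2 of the 3 values shown sit). Going by these compounds, whether (4-methoxyphenyl)sulfanyl in place of 4-fluorophenoxy changes the number at all, and in which direction, stays open.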